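The source may hold more compounds than are shown below. What is called first, only, known or untested is meant among the compounds shown, and "the series" means these compounds.

Measured so far:
compound 1 `CCCc1ccc(NC(=O)C2CCN(C/C=C/c3ccccc3)CC2)cc1` — 5210 nM
compound 2 `O=C(Nc1cc(-c2cccc(Br)c2)on1)C1CCN(C/C=C/c2ccccc2)CC1` — 4610 nM

In a functional assay on MGC-803 cells (Homo sapiens) for inhibition, read by MTT assay, with a stated time of 72 h (on this read-out higher numbers stand for weaker inhibition and lower numbers for stronger inhibition), compound 1 gives 5210 nM, the higher of the two numbers in hand; compound 2 gives 4610 nM, and the two lie within the scatter of each other, so no order between them can be read. Compound 3 `O=C(NCc1ccccc1)C1CCN(C/C=C/c2ccccc2)CC1` differs from compound 1 by benzyl in place of 4-propylphenyl on an amide-type nitrogen. Among the compounds with values here, no measured pair spans a change of this kind, so the step has no precedent among the numbers in hand. Both measured compounds sit close together at weak inhibition, and the change swaps 4-propylphenyl for benzyl on the amide-type nitrogen; the expectation is a step of a 1.5-fold higher number from compound 1 to compound 3 (0.19 log units; within the scatter) that is modest, if anything toward a higher number, and not clearly beyond the scatter. Compound 3 is expected at 8000 nM, with a range of 2500 nM to 25000 nM.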

Compound 3, half-maximal inhibitory concentration: > 100000 nM
Compound 3 ended at the assay's limit; the forecaster's own chance of this, stated with the estimate: 20%; at least 12-fold (1.09 log units) between middle value and limit.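

In this assay, benzyl in place of 4-propylphenyl on the amide-type nitrogen gives an at least 19-fold higher number from compound 1 to compound 3 (1.28 log units; beyond the scatter), the first sign that inhibition in this series depends on the group at this position. Compound 3 stands at > 100000 nM, which is a limit of the assay and not a number. The step therefore gives only a lower bound on the size of the change: the limit of > 100000 nM in this assay, at which 1 of the 3 values shown sits.

This single change leaves open whether the result follows from losing the propyl chain or from going from an aryl group to benzyl, and phenyl or 4-propylbenzyl on the same nitrogen would separate the two. Also open, from the compounds shown here alone, is whether 4-butylphenyl, with its longer chain, or a phenyl ring bearing an amine or a carboxylic acid in place of the propyl chain would retain inhibition.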